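Aryl swap on the tetrazole of compound 2

The source may hold more compounds than are shown below. What is called first, only, known or untested is meant among the compounds shown, and "the series" means these compounds.

Two compounds of the series have numbers in an assay on HEK293 cells for activation of Kir3.1/Kir3.2 (Homo sapiens), read by thallium flux; on this read-out lower numbers stand for an effect already at smaller amounts and higher numbers for an effect only at larger amounts of compound. Compound 1 `Cc1cc(NC(=O)Cn2nnc(-c3ccccc3)n2)n(C(C)C)n1` gives 556 nM in this assay. Compound 2 `Cc1cc(NC(=O)Cn2nnc(-c3ccc(F)cc3)n2)n(C2CCCCC2)n1` gives 180 nM in this assay and holds the lowest of the two numbers; compound 1 sits beyond the scatter above it. The two differ in more than one place at once, so the shown values give no single step that can be read on its own.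

Compound 3 `Cc1cccc(-c2nnn(CC(=O)Nc3cc(C)nn3C3CCCCC3)n2)c1` is not yet measured. It differs from compound 2 by 3-methylphenyl in place of 4-fluorophenyl on an aromatic carbon. Among the compounds with values here, no pair of measured compounds reproduces this change, so its size and direction cannot be taken from the series; the exchange keeps the size of the group and adds no donor or acceptor, and the effect of the fluorine in compound 2 cannot be separated from the other change against compound 1.

Compound 3 is therefore expected to stay close to compound 2, with the step from compound 2 to compound 3 estimated at a 1.4-fold higher number from compound 2 to compound 3 (0.14 log units; within the scatter), either way within or just beyond the scatter. The estimate for compound 3 in this assay is 250 nM, with a range from 90 nM to 700 nM.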

Compound 3, half-maximal effective concentration: 129 nM
For compound 3 the middle estimate is 1.9-fold (0.29 log units) above the measured one; low and high end bracket the measured number.
By their numbers in this assay, from the lowest: compounds 3 and 2 (each within the scatter of the next); then compound 1.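

In this assay, within the data shown here, the exchange of 4-fluorophenyl for 3-methylphenyl on the aromatic carbon between two ring nitrogen atoms gives a 1.4-fold lower number from compound 2 to compound 3 (0.14 log units; within the scatter) and is the first step that can be read on its own. This position therefore accepts a substituted phenyl without fluorine while the rest of compound 2 stays unchanged, so the fluorine is not required for a number in this range; the step changes the substituent and its place on the phenyl ring together, and these two contributions cannot be separated. No measurement at hand explains why this exchange leaves the number within the scatter.

Still open, as far as these compounds go, is how an unsubstituted phenyl would read on the rest of compound 2, which would show whether either substituent contributes at all and how much of the gap to compound 1 belongs to the aryl group. Also open, from the compounds shown here alone, is whether this position accepts a phenyl bearing an amine or a carboxylic acid as it accepts the methyl and the fluorine.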